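Trading bromo for fluoro: what one step suggests

This account rests on a few compounds, and the source may have more. Where it says the series, first, only, none or still open, it means among the compounds named here.

In a functional assay on A549 cells (Homo sapiens) for antiproliferative activity, read by MTT assay, with a stated time of 72 h (on this read-out lower numbers stand for stronger inhibition and higher numbers for weaker inhibition), compound 1 (`O=C(N/N=C/c1ccccc1)Nc1ccc(Oc2ccnc3[nH]ccc23)cc1`) gives 17200 nM and compound 2 (`O=C(N/N=C/c1ccc(Br)cc1)Nc1ccc(Oc2ccnc3[nH]ccc23)cc1`) gives 640 nM on the same read-out. Within the data shown here, compound 2 therefore holds the lower of the two numbers, and compound 1 is its only measured neighbour. Compound 3 (`O=C(N/N=C/c1ccc(F)cc1)Nc1ccc(Oc2ccnc3[nH]ccc23)cc1`) keeps the core of compound 2 and alters one substituent, as follows: fluoro in place of bromo on an aromatic carbon (fluoro in place of bromo on an aromatic carbon, para to a large group). Among the measured compounds shown here, only one measured step bears on this change, namely a 27-fold lower number from compound 1 to compound 2 (1.43 log units; beyond the scatter) and it is bromo in place of hydrogen on an aromatic carbon. For the measured compounds named here, no fluoro compound has been measured, so the data do not show how much of that gain fluoro would keep. Compound 3 is expected to fall between compound 2 and compound 1, and to retain a good part of the gain seen in a 27-fold lower number from compound 1 to compound 2 (1.43 log units; beyond the scatter) without matching it. The estimated change is a 3.9-fold higher number from compound 2 to compound 3 (0.59 log units; beyond the scatter) towards a higher number. For compound 3 the estimated value is 2500 nM with an expected range from 700 nM to 9000 nM on this read-out.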

Compound 3, half-maximal inhibitory concentration: 1430 nM
Beside the measured number, compound 3's estimate is 1.7-fold (0.24 log units) above it, within the range that was stated.
By their numbers in this assay, from the lowest: compound 2; then compound 3; then compound 1.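

In this assay the new result shows that the gain at this position does not belong to bromo alone: fluoro on the same aromatic carbon also brings a large drop (a 12-fold lower number from compound 1 to compound 3 (1.08 log units; beyond the scatter)), so compound 1, with hydrogen there, stays well behind both halogen compounds. The exchange of one halogen for the other matters less but is still real (a 2.2-fold higher number from compound 2 to compound 3 (0.35 log units; beyond the scatter)), which leaves bromo ahead of fluoro, while most of the gain seen for bromo (a 27-fold lower number from compound 1 to compound 2 (1.43 log units; beyond the scatter)) survives the exchange. No measurement available here explains why either halogen lowers the number or why the two differ.

The compounds shown leave open whether a halogen is needed at all, since a methoxy group, a nitrile or an amine on this carbon could give a quite different number. They also leave open whether chloro would land nearer compound 2 or compound 3, and whether the order of bromo and fluoro would hold on any other cell line.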